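Alkene methyl removal in a diaryl urea series

The compounds below may be only part of what the source reports. "The series", "measured", "known", "first", "only" and "open" are said of these compounds alone.

Compound 1 `C/C(=C\c1ccc(NC(=O)Nc2ccc(Cl)c(C(F)(F)F)c2)cc1)C(=O)N1CC(C)OC(C)C1` in a functional assay on KETR3 cells (Homo sapiens) for inhibition, read by MTT assay, with a stated time of 120 h (on this read-out lower numbers stand for stronger inhibition and higher numbers for weaker inhibition), given as a limit only: > 50000 nM
Compound 2 `CNC(=O)/C=C(\C)c1ccc(NC(=O)Nc2ccc(Cl)c(C(F)(F)F)c2)cc1`, given as a limit only: > 50000 nM
Compound 3 `C/C(=C\C(=O)NC(C)c1ccccc1)c1ccc(NC(=O)Nc2ccc(Cl)c(C(F)(F)F)c2)cc1`, given as a limit only: > 50000 nM

Compound 2 stands in this assay only as a limit, and the two further values shown are limits as well, so nothing separates the three compounds on the numbers. Among the compounds with values here, the single step inside the measured set, a step that the two limits leave unreadable from compound 2 to compound 3, has no readable size, as both of its ends sit at the limit of > 50000 nM in this assay, at which 3 of the 3 values shown sit.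

Compound 4 `CNC(=O)/C=C/c1ccc(NC(=O)Nc2ccc(Cl)c(C(F)(F)F)c2)cc1` differs from compound 2 as follows:
2-(methylcarbamoyl)ethenyl in place of 1-methyl-2-(methylcarbamoyl)ethenyl on an aromatic carbon
Within the data shown here, no measured step bears on this change with a readable size; every value in the set is a limit, and the change itself is confined to the ethenyl linker. For compound 4 the expected step of a number no higher from compound 2 to compound 4 (the limit leaves the size open) is therefore none beyond the scatter, with the value most likely again reported only as a limit. The estimate for compound 4 in this assay is 50000 nM, with a range from 10000 nM to 250000 nM.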

Compound 4, half-maximal inhibitory concentration: 21200 nM
Beside the measured number, compound 4's estimate is 2.4-fold (0.37 log units) above it; the measured number falls inside the stated range.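

In this assay, 2-(methylcarbamoyl)ethenyl in place of 1-methyl-2-(methylcarbamoyl)ethenyl on the aromatic carbon gives an at least 2.3-fold lower number from compound 2 to compound 4 (0.37 log units; beyond the scatter), so loss of the alkene methyl moves the read-out where the earlier step, between compound 2 and compound 3, cannot be read. Compound 4, at 21200 nM, is the only compound shown with a number rather than a limit, and it gives the series its first measured anchor, though a weak one. Compound 2 is itself a limit, so the full size of the step stays unknown, and the rest of the set remains at that limit: the limit of > 50000 nM in this assay, at which 3 of the 4 values shown sit.

Going by these compounds, whether the same methyl removal reads similarly with the amides of compound 1 and compound 3 stays open. Also open, on these data alone, is how a carboxylic acid in place of the methylcarbamoyl end, or a longer chain on the amide nitrogen, would read on the linker of compound 4.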